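A few compounds are considered here, and "the series" means these few. Any claim that something is new, unique, unknown or untested is made for them only; others in the source may bear on it.

Compound 2 `CN(C)C1(Cc2ccccc2)CCN(c2cc(C(F)(F)F)ccc2CNC(=O)Nc2ccc(CNS(C)(=O)=O)c(F)c2)CC1` carries a methanesulfonamido group on the chain carbon that joins the aromatic ring of the urea side. In an assay on CHO cells for antagonist activity at transient receptor potential cation channel subfamily V member 1 (Homo sapiens), read by scintillation counting, with a stated time of 5 min, in the presence of a further agent that is not named here (a lower number here means that less compound is needed, a higher number that more compound is needed for the effect), compound 2 gives 25 nM, the higher of the two numbers in hand, while compound 1 `CC(C(=O)NCc1ccc(C(F)(F)F)cc1N1CCC(Cc2ccccc2)(N(C)C)CC1)c1ccc(NS(C)(=O)=O)c(F)c1`, which differs from it in several places, gives 8.2 nM. Compound 3 `CN(C)C1(Cc2ccccc2)CCN(c2cc(C(F)(F)F)ccc2CNC(=O)Nc2ccc(CO)c(F)c2)CC1` keeps the core of compound 2 and makes one change: hydroxy in place of methanesulfonamido on a saturated chain carbon bound to an aromatic carbon. Within the data shown here, no measured pair shows this exact change, so the direction rests on expectation alone. A moderate loss is expected, with the step from compound 2 to compound 3 estimated at a 3.2-fold higher number from compound 2 to compound 3 (0.51 log units; beyond the scatter), somewhat beyond the scatter. Compound 3 is therefore estimated at 80 nM, within a range from 25 nM to 300 nM.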

Compound 3, half-maximal effective concentration: 81 nM
Estimate against measurement, compound 3: 1.0-fold (0.01 log units) below; low and high end bracket the measured number.
By their numbers in this assay, from the lowest: compound 1; then compound 2; then compound 3.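

Among these compounds, this is the first pair that differs in only one place, and it shows that the group on this chain carbon affects the result: in this assay, the change from methanesulfonamido to hydroxy gives a 3.2-fold higher number from compound 2 to compound 3 (0.51 log units; beyond the scatter). The step is beyond the usual scatter, yet compound 3 still gives a measured number. Nothing shown here gives a cause for this step. Still open, on these data alone, is how an amine or a carboxylic acid on the same carbon would compare with hydroxy. A single pair also cannot show whether this step would hold on another core.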